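Series notes: remote aryl substituent and acid dissociation

The source may report more compounds than this note shows. Statements on the series, on what has been measured and on what is new or still open speak of the compounds shown alone.

Compound 1 `COc1cccc(CNCCCNc2ccnc3cc(-c4ccc(C(C)(C)C)cc4)ccc23)c1O` is measured in a physicochemical assay for acid dissociation, and gives 9.47. Compound 2 `COc1ccc(F)cc1CNCCCNc1ccnc2cc(-c3ccc(C(C)(C)C)cc3)ccc12` gives 9.47. On these two numbers compound 1 stands level with compound 2; the step of no change at the digits printed from compound 1 to compound 2 (within the scatter) is a change at the group on a saturated chain carbon bound to an amine nitrogen, and it leaves the read-out unmoved.

Compound 3 `COc1cccc(CNCCCNc2ccnc3cc(-c4ccc(C(F)(F)F)cc4)ccc23)c1O` is not yet measured in this assay. Its difference from compound 1 is trifluoromethyl in place of tert-butyl on an aromatic carbon. This change sits on the aromatic ring of carbon only at the end of the shared core opposite to the chain, far from the amine nitrogens of the chain.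

Going by the values given here, no measured step covers an exchange at this aromatic carbon. Among the compounds with values here, the only step known, from compound 1 to compound 2, altered an aryl group on the chain and produced no change within the scatter. Nothing in the data suggests that the read-out responds to the group on the far aromatic ring, so the expected step from compound 1 to compound 3 is a number 0.07 log units lower from compound 1 to compound 3 (within the scatter), none beyond the scatter. The estimate for compound 3 in this assay is therefore 9.4, with a range from 9 to 9.8.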

Compound 3, acid dissociation constant: 9.47
Compound 3: the middle estimate sits 0.07 log units below what was measured; the measured number falls inside the stated range.
By their numbers in this assay, from the lowest: compounds 1, 2 and 3 (each within the scatter of the next).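

In this assay, the exchange of 4-(tert-butyl)phenyl to 4-(trifluoromethyl)phenyl gives no change at the digits printed from compound 1 to compound 3 (within the scatter), a reading at this aromatic carbon that the earlier step, made on the aryl group of the chain, could not supply. Tert-butyl and trifluoromethyl, with the same heavy-atom count but one all carbon and the other carrying three fluorine atoms, read alike here, so on this single pair the read-out does not respond to this exchange at this position. No measurement at hand speaks to why the read-out stays put.

As far as these compounds go, with one exchange read at this carbon, no trend across groups there can be stated, and whether an amine or a carboxylic acid in the same place would also leave the read-out unmoved remains open. Going by these compounds alone, also open is how the read-out would answer a longer chain in place of the chain that carries the amine nitrogens, since the steps so far leave that chain unchanged.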